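Iodo in place of fluoro on an aromatic carbon

A few compounds are considered here, and "the series" means these few. Any claim that something is new, unique, unknown or untested is made for them only; others in the source may bear on it.

In a physicochemical assay for solubility, read by spectrophotometry, in phosphate buffer, with a stated time of 18 h, at pH 7.4 (on this read-out higher numbers stand for higher solubility and lower numbers for lower solubility), compound 1 `CCCc1ccc(-c2nc3c(c(C)nn3-c3ccccc3)c(-c3ccccc3O)c2C#N)cc1` gives 6500 nM and compound 2 `Cc1nn(-c2ccccc2)c2nc(-c3ccc(F)cc3)c(C#N)c(-c3ccccc3O)c12` gives 6000 nM in the same test, so compound 2 stands level with compound 1 within the usual scatter of repeated measurements. Compound 3 `Cc1nn(-c2ccccc2)c2nc(-c3ccc(I)cc3)c(C#N)c(-c3ccccc3O)c12` differs from compound 2 in one place (iodo in place of fluoro on an aromatic carbon) with iodo in place of fluoro on an aromatic carbon, turning 4-fluorophenyl into 4-iodophenyl. Within the data shown here, only one measured step bears on this, fluoro in place of propyl on an aromatic carbon, and it is small: a 1.1-fold lower number from compound 1 to compound 2 (0.03 log units; within the scatter) and so no real change. Among the measured compounds shown here, no measured compound carries iodo, so this single step is thin evidence. On that basis no step beyond the scatter is expected in this assay here, and the estimated step is a 1.1-fold lower number from compound 2 to compound 3 (0.04 log units; within the scatter) at most a minor one. Compound 3 is expected at 5500 nM with an estimated range from 2500 nM to 9500 nM around that figure.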

Compound 3, solubility: 1500 nM
The estimate for compound 3 lay 3.7-fold (0.56 log units) above the measured number; measured number below the stated range.
By their numbers in this assay, from the lowest: compound 3; then compounds 2 and 1 (each within the scatter of the next).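

In this assay the position para to a large group on this aromatic ring is not indifferent to its substituent, since swapping fluoro for iodo gives a 4.0-fold lower number from compound 2 to compound 3 (0.60 log units; beyond the scatter) and so a real change. The earlier swap of propyl for fluoro had moved the number only within the scatter, which made the position look tolerant, but iodo in place of propyl now gives a 4.3-fold lower number from compound 1 to compound 3 (0.64 log units; beyond the scatter) as well, so iodo stands apart from both of the other groups. Nothing measured here explains why the number falls with iodo.

The compounds shown leave open whether chloro or bromo at this place would read like fluoro or like iodo. Among these compounds, they also leave open whether an amine or a carboxylic acid here would lift the number above those of the compounds so far.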